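The source may report more compounds than this note shows. Statements on the series, on what has been measured and on what is new or still open speak of the compounds shown alone.

Compound 1 `CC(C)(NC(=O)COc1ccc2[nH]c(=O)c(-c3ccccn3)c(CCc3ccccc3)c2c1)c1ccccc1` and compound 2 `CC(C)(NC(=O)COc1ccc2[nH]c(=O)c(-c3cccnc3)c(CCc3ccccc3)c2c1)c1ccccc1` share a core and differ only in the small aromatic ring attached to it. In a functional assay on CHO cells for antagonist activity at adenosine receptor A2b (Homo sapiens), read by cAMP accumulation, with stated times of 15 min and 1 h (a lower number here means a stronger inhibitor, a higher number a weaker inhibitor), compound 1 gives 504 nM, and compound 2 gives 187 nM. The swap of one ring for another brings a 2.7-fold lower number from compound 1 to compound 2 (0.43 log units; beyond the scatter). A third member of the series, compound 3 `Cn1c(=O)c(S(C)(=O)=O)c(CCc2ccccc2)c2cc(OCC(=O)NCc3ccc(Cl)c(Cl)c3)ccc21`, carries a methylsulfonyl group at the same position together with other changes to the core and the amide; in this assay compound 3 reaches only the limit > 5000 nM, which is a boundary of the measurement rather than a number, as noted in the limit of > 5000 nM in this assay, at which 1 of the 3 values shown sits. Among the two real numbers compound 2 stands as the lower one.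

Compound 4 `Cc1cc(-c2c(CCc3ccccc3)c3cc(OCC(=O)NC(C)(C)c4ccccc4)ccc3[nH]c2=O)on1` keeps everything of compound 2 except that ring: 3-methyl-1,2-oxazol-5-yl in place of pyridin-3-yl on an aromatic carbon. For the measured compounds named here, the one comparable step, the ring swap that gave a 2.7-fold lower number from compound 1 to compound 2 (0.43 log units; beyond the scatter), was modest, so a change of similar size in either direction, or none beyond the scatter, is expected. For compound 4 the estimate in this assay is 260 nM, within the range 100 nM to 700 nM, meaning an expected step of a 1.4-fold higher number from compound 2 to compound 4 (0.14 log units; within the scatter).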

Compound 4, inhibition constant: 31 nM
The estimate for compound 4 lay 8.4-fold (0.92 log units) above the measured number; the measured number lies below the stated range.
By their numbers in this assay, from the lowest: compound 4; then compound 2; then compound 1. At a limit, above all of these: compound 3.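

The ring at this position can do more than shift the number slightly: in this assay, the change to a five-membered ring gives a 6.0-fold lower number from compound 2 to compound 4 (0.78 log units; beyond the scatter) and makes compound 4 the lowest real number shown. Across the three ring choices, the span reaches a 16-fold lower number from compound 1 to compound 4 (1.21 log units; beyond the scatter) and is the only step here counted as large. Since pyridin-3-yl and 3-methyl-1,2-oxazol-5-yl each have 6 heavy atoms, heavy-atom count alone does not set the number. Ring size, hetero atoms and the methyl group all change together, and nothing shown separates their shares or explains the gain.

Still open, on these data alone, is whether the methyl group matters, which an unsubstituted 1,2-oxazol-5-yl ring would test. Also open, as far as these compounds go, is how other five-membered rings, such as a thiazole or a pyrazole, would compare at this position.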